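The source may report more compounds than this note shows. Statements on the series, on what has been measured and on what is new or still open speak of the compounds shown alone.

In a functional assay on DLD-1 cells (Homo sapiens) for antiproliferative activity, read by CellTiter-Glo, with a stated time of 72 h (a lower number here means a stronger inhibitor, a higher number a weaker inhibitor), compound 1 `CC1CCN(C2CCN(S(=O)(=O)c3ccc(C#N)cc3)CC2)CC1` gives 2800 nM. Within the data shown here, only one other compound has a measured value so far: compound 2 `CC1CCN(C2CCN(S(=O)(=O)c3cnc(Cl)s3)CC2)CC1`, at 1800 nM. Among the measured compounds shown here, these two values lie within the scatter of each other, so compound 1 cannot be ranked against its only neighbour. Compound 3 `CC1CCN(C2CCN(S(=O)(=O)c3ccc(-c4ccccc4F)cc3)CC2)CC1` keeps the core of compound 1 but carries 2-fluorophenyl in place of cyano on an aromatic carbon, para to a large group: 2-fluorophenyl in place of cyano on an aromatic carbon. For the measured compounds named here, the only measured step, a 1.6-fold lower number from compound 1 to compound 2 (0.19 log units; within the scatter), replaced the whole group on the sulfonyl sulfur. Going by the values given here, it offers weak guidance, and no measured compound carries an added ring like this one. A modest move towards a lower number in this assay is therefore expected, with wide uncertainty. The expected step is a 2.8-fold lower number from compound 1 to compound 3 (0.45 log units; beyond the scatter). The estimate for compound 3 is 1000 nM, with an expected range of 200 nM to 4000 nM.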

Compound 3, half-maximal inhibitory concentration: 5 nM
Compound 3: the middle estimate sits 200-fold (2.30 log units) above what was measured; the whole stated range lies above it.
By their numbers in this assay, from the lowest: compound 3; then compounds 2 and 1 (each within the scatter of the next).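

Replacing cyano with 2-fluorophenyl on this aromatic carbon, para to a large group, gives a 560-fold lower number from compound 1 to compound 3 (2.75 log units; beyond the scatter) in this assay and marks this position as highly sensitive to what is placed there. The earlier comparison gave no sign of a change this large: a 1.6-fold lower number from compound 1 to compound 2 (0.19 log units; within the scatter) replaced the whole group on the sulfonyl sulfur and stayed far smaller. Nothing measured here explains the large change in compound 3.

Compound 3 brings in a new ring and a fluorine together, so the compounds shown do not separate their contributions, and a plain phenyl group would be the direct test. Also open, on these data alone, is whether a morpholine or a carboxylic acid on the same carbon would keep the number this low.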